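A few compounds are considered here, and "the series" means these few. Any claim that something is new, unique, unknown or untested is made for them only; others in the source may bear on it.

Compound 1 `CN1CCC(C(=O)N2Cc3c(NC(=O)Nc4cccc(F)c4)n[nH]c3C2(C)C)CC1` is measured in a physicochemical assay for solubility, at pH 7 (on this read-out lower numbers stand for lower solubility and higher numbers for higher solubility), where compound 1 gives > 225000 nM, which is a limit of the assay rather than a number. Compound 2 `CN1CCC(C(=O)Nc2n[nH]c3c2CN(C(=O)C(C)(C)C)C3(C)C)CC1` likewise reaches a limit, > 225000 nM. Compound 3 `CN(C)CC(=O)Nc1n[nH]c2c1CN(C(=O)C(C)(C)C)C2(C)C` also stops at a limit, > 225000 nM. Within the data shown here, the one measured step, a step that the two limits leave unreadable from compound 2 to compound 3, is therefore unreadable, and the only guide is the limit of > 225000 nM in this assay, at which 3 of the 3 values shown sit. Compound 4 `CN1CCC(C(=O)N2Cc3c(NC(=O)c4ccc(F)c(F)c4)n[nH]c3C2(C)C)CC1` differs from compound 1 by 3,4-difluorophenyl in place of (3-fluorophenyl)amino on a carbonyl carbon. Among the measured compounds shown here, no measured step concerns this change, so the expectation rests on where compound 1 stands, at the limit. Compound 4 is estimated at 200000 nM, within 50000 nM to 225000 nM. The expected step of an at least 1.1-fold lower number from compound 1 to compound 4 (0.05 log units; that floor lies within the scatter) is thus no change beyond the scatter, with the limit likely reached again.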

Compound 4, solubility: > 225000 nM
Compound 4 was reported as a limit; the forecaster's own chance of this, stated with the estimate: 60%; middle value at least 1.1-fold (0.05 log units) from the limit.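

Compound 1 and compound 4 both stop at a limit in this assay, so the step between them cannot be read. The compounds shown leave open how their true values compare, since all of them end at the same limit: the limit of > 225000 nM in this assay, at which 4 of the 4 values shown sit.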